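Removing a Chloro Group From the Second Benzyl Arm

This account rests on a few compounds, and the source may have more. Where it says the series, first, only, none or still open, it means among the compounds named here.

Measured compounds:
- compound 1, `O=C1c2ccccc2N(Cc2ccccc2Cl)S(=O)(=O)N1Cc1ccccc1Cl`: > 20000 nM in a functional assay on HEL cells (Homo sapiens); a lower number here means that less compound is tolerated, a higher number that more compound is tolerated
- compound 2, `O=S1(=O)N=C(OCc2ccccc2)c2ccccc2N1Cc1ccc(Cl)c(Cl)c1`: 200000 nM
- compound 3, `O=C1c2ccccc2N(Cc2ccccc2)S(=O)(=O)N1Cc1ccccc1Cl`: 200000 nM

The value of compound 1 is a limit of this assay, not a number; compound 1 was tolerated up to the highest concentration that was read, so only this limit is known (the limit of > 20000 nM in this assay, at which 1 of the 3 values shown sits). Compound 2 and compound 3 both reach a measured value.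

The step from compound 1 to compound 3 is one the data cannot size, a step that the limit leaves unreadable from compound 1 to compound 3, because the value of compound 1 is a limit (the limit of > 20000 nM in this assay, at which 1 of the 3 values shown sits).

Compound 4, `O=C1c2ccccc2N(Cc2ccccc2Cl)S(=O)(=O)N1Cc1ccccc1`, is not yet measured. It differs from compound 1 by hydrogen in place of chloro on an aromatic carbon, that is, 2-chlorobenzyl to benzyl on the other arm of the shared core.

Within the data shown here, the only step that bears on this change is the one from compound 1 to compound 3, which is unreadable, so no direction beyond the scatter can be expected from it alone. Compound 3 stands at 200000 nM, and compound 4 is expected to lie near that level: the estimate for compound 4 is 200000 nM, with a range from 40000 nM to 400000 nM, which means an expected step that the limit leaves unreadable from compound 1 to compound 4.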

Compound 4, minimum cytotoxic concentration: 200000 nM
For compound 4 middle estimate and measured number coincide at the digits printed, and the stated range covers the measured number.
By their numbers in this assay, from the lowest: compounds 2, 3 and 4 (each within the scatter of the next).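

No new step can be read from compound 1 to compound 4, because the value of compound 1 is only a limit of the assay: the limit of > 20000 nM in this assay, at which 1 of the 4 values shown sits.

The compounds shown leave open whether replacing 2-chlorobenzyl with benzyl on the shared core changes the minimum cytotoxic concentration in this assay at all, and by how much.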